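Stripping the chain down: compound 3 to compound 4

The compounds below may be only part of what the source reports. "The series", "measured", "known", "first", "only" and "open" are said of these compounds alone.

Measured compounds in an in vitro functional assay on 1321-N1 cells for agonist activity at P2Y purinoceptor 4 (Homo sapiens); on this read-out lower numbers stand for an effect already at smaller amounts and higher numbers for an effect only at larger amounts of compound:
compound 1, `Cn1c(=O)ccn([C@@H]2O[C@H](COP(=O)(O)OP(=O)(O)OP(=O)(O)O)[C@@H](O)[C@H]2O)c1=O`, 2920 nM;
compound 2, `O=c1[nH]c(=O)n([C@@H]2O[C@H](COP(=O)(O)OP(=O)(O)OP(=O)(O)O)[C@@H](O)[C@H]2O)cc1Br`, 3460 nM;
compound 3, `O=c1[nH]c(=O)n([C@@H]2O[C@H](COP(=O)(O)OP(=O)(O)O)[C@@H](O)[C@H]2O)cc1Br`, 7200 nM.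

Among these three, compound 3 has the highest number in this assay: a 2.1-fold higher number from compound 2 to compound 3 (0.32 log units; beyond the scatter), and against compound 1 the gap is wider still. Its neighbour compound 2 differs from compound 1 by a 1.2-fold higher number from compound 1 to compound 2 (0.07 log units; within the scatter), a change on the ring part of the shared core that changed little.

Compound 4, `O=c1[nH]c(=O)n([C@@H]2O[C@H](COP(=O)(O)O)[C@@H](O)[C@H]2O)cc1Br`, is made from compound 3 by a hydrogen atom in place of a group of 4 heavy atoms (3 oxygen, 1 phosphorus; no ring), on an oxygen. This repeats the kind of change already seen between compound 2 and compound 3, where the chain was shortened by one such group: a 2.1-fold higher number from compound 2 to compound 3 (0.32 log units; beyond the scatter). For the measured compounds named here, only that single step bears on the new one, and here the chain is cut down a second time, leaving the shortest chain of the series. A further rise in the number is therefore expected, and a larger one than before, with a real chance that the assay yields only a limit. The expected step is a 6.9-fold higher number from compound 3 to compound 4 (0.84 log units; beyond the scatter). For compound 4 the estimate is 50000 nM, in a range from 12000 nM to 300000 nM.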

Compound 4, half-maximal effective concentration: > 100000 nM
Compound 4: only a limit was reported; the forecaster's own chance of this, stated with the estimate: 40%; middle value at least 2.0-fold (0.30 log units) away from the limit.
By their numbers in this assay, from the lowest: compounds 1 and 2 (each within the scatter of the next); then compound 3. At a limit, above all of these: compound 4.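

In this assay, compound 4 gives no number, only a limit: the limit of > 100000 nM in this assay, at which 1 of the 4 values shown sits.

Taking away the group of 4 heavy atoms (3 oxygen, 1 phosphorus) on an oxygen had only a modest effect the first time, a 2.1-fold higher number from compound 2 to compound 3 (0.32 log units; beyond the scatter), but the same kind of change is large when made again, an at least 13-fold higher number from compound 3 to compound 4 (1.14 log units; beyond the scatter). Over both cuts together the shift is an at least 28-fold higher number from compound 2 to compound 4 (1.46 log units; beyond the scatter), so in this short series the effect of shortening the chain is not an even stepwise one: the last cut, which leaves the shortest chain, counts for most.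

Going by these compounds, the true size of these last two steps stays open, as only a limit stands at their end. Also open, on these data alone, is whether a carboxylic acid or an amine on that oxygen could take the place of the lost group and bring the number back towards that of compound 3.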